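This account rests on a few compounds, and the source may have more. Where it says the series, first, only, none or still open, it means among the compounds named here.

In a functional assay on MCF7 cells (Homo sapiens) for antiproliferative activity, read by MTT assay, with a stated time of 24 h (on this read-out higher numbers stand for weaker inhibition and lower numbers for stronger inhibition), compound 1 `Cc1ccc(-c2nn(-c3ccccc3)cc2-c2nc3ccccc3[nH]2)cc1` gives 7260 nM, compound 2 `Cc1ccc(-c2nn(-c3ccccc3)cc2-c2nc3ccccc3n2S(=O)(=O)c2ccccc2)cc1` gives 830 nM and compound 3 `Cc1ccc(-c2nn(-c3ccccc3)cc2-c2nc3ccccc3n2S(=O)(=O)c2cc(C)ccc2C)cc1` gives 510 nM. Compound 3 thus stands with compound 2 at the low end of the three numbers. Putting a sulfonyl group on the aromatic nitrogen gave an 8.7-fold lower number from compound 1 to compound 2 (0.94 log units; beyond the scatter) and a 14-fold lower number from compound 1 to compound 3 (1.15 log units; beyond the scatter). Compound 4 `Cc1ccc(-c2nn(-c3ccccc3)cc2-c2nc3ccccc3n2S(=O)(=O)c2ccc(F)cc2)cc1` keeps that sulfonyl group and carries 4-fluorophenyl in place of 2,5-dimethylphenyl on a sulfonyl sulfur, that is, 4-fluorophenyl in place of 2,5-dimethylphenyl on a sulfonyl sulfur. Among the measured compounds shown here, the one measured change of this group, a 1.6-fold lower number from compound 2 to compound 3 (0.21 log units; within the scatter), was small, so no step beyond the scatter is expected here. The estimate for this change is a 1.4-fold higher number from compound 3 to compound 4 (0.14 log units; within the scatter). Compound 4 is expected at 700 nM, with an estimated range of 300 nM to 1600 nM.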

Compound 4, half-maximal inhibitory concentration: 5270 nM
Compound 4: the middle estimate sits 7.5-fold (0.88 log units) below what was measured; measured number above the stated range.
By their numbers in this assay, from the lowest: compounds 3 and 2 (each within the scatter of the next); then compounds 4 and 1 (each within the scatter of the next).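

The aryl group on the sulfonyl sulfur proves a sensitive position: 4-fluorophenyl in place of 2,5-dimethylphenyl (a 10-fold higher number from compound 3 to compound 4 (1.01 log units; beyond the scatter)) and fluoro in place of hydrogen on an aromatic carbon (a 6.3-fold higher number from compound 2 to compound 4 (0.80 log units; beyond the scatter)) both give steps beyond the scatter. The sulfonyl group alone therefore does not secure the lower numbers of compound 2 and compound 3, since (4-fluorophenyl)sulfonyl in place of hydrogen stays within the scatter (a 1.4-fold lower number from compound 1 to compound 4 (0.14 log units; within the scatter)). No available evidence explains this reversal.

Going by these compounds, whether the reversal is specific to fluoro remains open. Chloro, methoxy or an amine in its place would test this.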